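Swapping Methoxy for Methylamino on a Weaker Core

The compounds below may be only part of what the source reports. "The series", "measured", "known", "first", "only" and "open" are said of these compounds alone.

Compound 1 `COc1ncnc2c1c(-c1cccs1)cn2[C@@H]1O[C@H](CO)[C@@H](O)[C@H]1O` carries a methoxy group on the shared core together with a thiophen-2-yl substituent. In a functional assay on HL-60 cells (Homo sapiens) for antiproliferative activity, read by XTT assay, with a stated time of 72 h (a lower number here means a stronger inhibitor, a higher number a weaker inhibitor), compound 1 gives 80 nM. Compound 2 `CNc1ncnc2c1c(-c1cccs1)cn2[C@@H]1O[C@H](CO)[C@@H](O)[C@H]1O` differs from compound 1 in one place: methylamino in place of methoxy on an aromatic carbon. For compound 2 this assay reports only a limit, > 20000 nM, not a number. The change from compound 1 to compound 2 thus produces an at least 250-fold higher number from compound 1 to compound 2 (2.39 log units; beyond the scatter), and the limit of > 20000 nM in this assay, at which 1 of the 3 values shown sits, is where that value sits.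

Compound 3 `COc1ncnc2c1c(-c1cc3ccccc3o1)cn2[C@@H]1O[C@H](CO)[C@@H](O)[C@H]1O` keeps the methoxy group but alters the substituent on the core: 1-benzofuran-2-yl in place of thiophen-2-yl on an aromatic carbon. In this assay compound 3 gives 4470 nM, which is a 56-fold higher number from compound 1 to compound 3 (1.75 log units; beyond the scatter).

Compound 4 `CNc1ncnc2c1c(-c1cc3ccccc3o1)cn2[C@@H]1O[C@H](CO)[C@@H](O)[C@H]1O` has not yet been measured in this assay. It differs from compound 3 by methylamino in place of methoxy on an aromatic carbon, the same change, at the same place, that separates compound 2 from compound 1. Since compound 3 already stands at 4470 nM and the earlier change gave an at least 250-fold higher number from compound 1 to compound 2 (2.39 log units; beyond the scatter), compound 4 is expected to land well past the edge of what this assay can measure. The step this estimate implies, a 34-fold higher number from compound 3 to compound 4 (1.53 log units; beyond the scatter), is expected to be of a size like the earlier one, though only a limit can show it. Compound 4 is therefore estimated at 150000 nM, most likely reported as a limit, within an expected range of 15000 nM to 2000000 nM.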

Compound 4, half-maximal inhibitory concentration: 8950 nM
Beside the measured number, compound 4's estimate is 17-fold (1.22 log units) above it; the whole stated range lies above it.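

With 1-benzofuran-2-yl on the shared core, methylamino in place of methoxy gives a 2.0-fold higher number from compound 3 to compound 4 (0.30 log units; within the scatter), so in this assay this change does not repeat the large step seen with thiophen-2-yl, and the two steps differ: the same change on two cores in this assay, an at least 250-fold higher number (2.39 log units; beyond the scatter) from compound 1 to compound 2 and a 2.0-fold higher number (0.30 log units; within the scatter) from compound 3 to compound 4, at least 120-fold (2.09 log units) apart, beyond the scatter of two such steps

The other change also depends on its partner, as 1-benzofuran-2-yl in place of thiophen-2-yl gives an at least 2.2-fold lower number from compound 2 to compound 4 (0.34 log units; beyond the scatter) when methylamino is present, a step in the opposite direction to the one seen when methoxy is present: the same change on two cores in this assay, a 56-fold higher number (1.75 log units; beyond the scatter) from compound 1 to compound 3 and an at least 2.2-fold lower number (0.34 log units; beyond the scatter) from compound 2 to compound 4, at least 120-fold (2.09 log units) apart, beyond the scatter of two such steps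

Compound 2 gives only a limit, > 20000 nM, and these two cores show that the methylamino change does not carry over unchanged, but not why, nor what it would do on any other core.

The compounds shown leave open whether the same dependence holds for other groups in the place of methoxy, such as ethoxy, a plain amine or dimethylamino, or for other substituents in the place of thiophen-2-yl, such as furan-2-yl or phenyl. They also leave open whether the pattern would appear in any other test.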